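The source may hold more compounds than are shown below. What is called first, only, known or untested is meant among the compounds shown, and "the series" means these compounds.

Measured so far in a functional assay on the whole organism for inhibition, with Rattus norvegicus as the target, with a stated time of 30 min, at a dose of 1 mg/kg by the intravenous route; on this read-out lower numbers stand for less inhibition and higher numbers for more inhibition at the one dose given (going by the name of the read-out):
- compound 1 `O=C(Nc1nnn[nH]1)c1ccc2occc(=O)c2c1`: 35%
- compound 2 `N#Cc1ccc2oc(C(=O)Nc3nnn[nH]3)cc(=O)c2c1`: 100%
- compound 3 `O=C(O)CCNC(=O)c1cc(=O)c2ccccc2o1`: 0%

Compound 2 stands highest of the three numbers in this assay. The nearest number is that of compound 1, a gap beyond the scatter; the furthest is that of compound 3, also beyond the scatter. Within the data shown here, no pair among the measured compounds differs in one place only, so no single-change step is available to calibrate the move to compound 4.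

Compound 4 `O=C(Nc1nnn[nH]1)c1cc(=O)c2cc(Cl)ccc2o1` has not yet been measured in this assay. It differs from compound 2 by chloro in place of cyano on an aromatic carbon. What this change does to inhibition cannot be read from the measured compounds; compounds 1 and 3 carry other differences and give no guide to this one. Compound 2 sits at the top of the scale, so the expected direction is downward or none, and the size of the step is expected to be modest, possibly within the scatter. Compound 4 is expected to give 75% (range 45% to 100%), a step of a number 25 percentage points lower from compound 2 to compound 4 (beyond the scatter) that is estimated, not measured.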

Compound 4, a percentage reported as inhibition, in the whole organism at one dose (the size of the read-out at that dose, not a potency): 65%
Compound 4: middle estimate off by 10 percentage points, on the high side, and the stated range covers the measured number.
By their numbers in this assay, from the lowest: compound 3; then compound 1; then compound 4; then compound 2.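

In this assay, the series now has its first comparison that differs in one place: with chloro in place of cyano on an aromatic carbon of the six-membered aromatic ring of carbon only, there is a number 35 percentage points lower from compound 2 to compound 4 (beyond the scatter). This position is therefore not indifferent to the group it carries, although compound 4 still retains substantial inhibition at 65%. No measurement available here accounts for the size of this step.

With only cyano and chloro compared at this position, no trend across groups can be read, and a fluoro, a methoxy or an amine on this aromatic carbon could fall anywhere relative to them. As far as these compounds go, whether the same change gives a step of similar size alongside a different side chain, such as the carboxylic acid chain of compound 3, also remains open.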